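From fluoro to 3-fluorophenyl at the assay limit

The compounds below may be only part of what the source reports. "The series", "measured", "known", "first", "only" and "open" are said of these compounds alone.

Compound 1 `O=C(Nc1ccc(OC(F)(F)F)cc1)c1cc(=O)[nH]c2cc(Br)ccc12`: > 20000 nM
Compound 2 `O=C(Nc1cccc(F)c1)c1cc(=O)[nH]c2cc(F)ccc12`: > 20000 nM
Compound 3 `O=C(Nc1cc(F)cc(F)c1)c1cc(=O)[nH]c2cc(F)ccc12`: > 20000 nM

All three readings come from a functional assay on KYSE-70 cells for antiproliferative activity against KYSE-70 cell line (Homo sapiens), read by MTT assay, with a stated time of 72 h (a lower number here means a stronger inhibitor, a higher number a weaker inhibitor), and each is a limit, not a number. The whole series therefore rests on (the limit of > 20000 nM in this assay, at which 3 of the 3 values shown sit). Compound 2 stands at > 20000 nM, which is likewise only a limit, so its true position is not known.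

Compound 4 `O=C(Nc1cccc(F)c1)c1cc(=O)[nH]c2cc(-c3cccc(F)c3)ccc12` has not yet been measured. It differs from compound 2 by one change, (3-fluorophenyl in place of fluoro on an aromatic carbon), with 3-fluorophenyl in place of fluoro on an aromatic carbon.

Among the compounds with values here, the only measured step available is a step that the two limits leave unreadable from compound 2 to compound 3, with fluoro in place of hydrogen on an aromatic carbon. It is a different change, and it offers no size to carry over. Within the data shown here, no measured compound carries the entering group, so the expectation for this assay is weakly founded. The expectation rests on the limit of compound 2, > 20000 nM. A modest strengthening is the most that can be expected, and a reading that again gives only a limit is quite likely. The expected change is an at least 1.2-fold lower number from compound 2 to compound 4 (0.09 log units; that floor lies within the scatter). Compound 4 is estimated at 16000 nM, with an expected range from 6000 nM to 30000 nM.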

Compound 4, half-maximal inhibitory concentration: 12000 nM
Compound 4: the middle estimate sits 1.3-fold (0.12 log units) above what was measured; measured number inside the range.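

In this assay compound 4 gives the only reading of the series that is a number, 12000 nM, and it is the only compound shown with a ring at this position of the core, with 3-fluorophenyl in place of fluoro on an aromatic carbon. Compound 2 stands at > 20000 nM, which is a limit. The step is an at least 1.6-fold lower number from compound 2 to compound 4 (0.22 log units; that floor lies within the scatter), so this change is shown to bring the reading inside the measured range but not to bring a gain beyond the scatter, and the other compounds still rest on one boundary: the limit of > 20000 nM in this assay, at which 3 of the 4 values shown sit.

The step between compound 2 and compound 3 cannot be read, and the compounds shown leave open whether the added ring or the fluoro on it matters for the reading, as a plain phenyl at this position would test. They also leave open how an amine, a morpholine or a carboxylic acid on the entering ring would read in this assay, and so whether this position can give a number well clear of the limit.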